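A few compounds are considered here, and "the series" means these few. Any claim that something is new, unique, unknown or untested is made for them only; others in the source may bear on it.

In a functional assay on Jurkat cells (Homo sapiens) for cytotoxicity, read by MTT assay, with a stated time of 24 h (a lower number here means that less compound is needed, a higher number that more compound is needed for the effect), compound 1 `CCOC(=O)c1cc([Se]c2ccccc2)c2cc(OC)ccc2n1` gives 102000 nM and compound 2 `CCOC(=O)c1cc([Te]c2ccccc2)c2cc(OC)ccc2n1` gives 77400 nM. For the measured compounds named here, these are the only two numbers so far, and compound 2 stands within the scatter of compound 1, so the two cannot be ranked. The next structure is compound 3 `CCOC(=O)c1cc(C#CCCO)c2cc(OC)ccc2n1`, which carries a 4-hydroxybut-1-yn-1-yl group on the aromatic carbon opposite the ring nitrogen: a group of 5 heavy atoms (4 carbon, 1 oxygen; no ring) in place of a group of 7 heavy atoms (6 carbon, 1 tellurium; one six-membered aromatic ring of carbon only), on an aromatic carbon. Neither selenium nor tellurium remains at that place. Going by the values given here, the one measured step, a 1.3-fold lower number from compound 1 to compound 2 (0.12 log units; within the scatter), exchanges selenium for tellurium and stays within the scatter. Among the compounds with values here, it bears on the new change only weakly, since no measured compound carries a chain of this kind at that place. Within the data shown here, with no measured step pointing either way, no shift beyond the scatter is expected, and the estimated step is a 1.3-fold higher number from compound 2 to compound 3 (0.11 log units; within the scatter). This expectation is loose. For compound 3 the estimated value is 100000 nM, with an expected range from 35000 nM to 300000 nM.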

Compound 3, half-maximal effective concentration: 123000 nM
Compound 3: the middle estimate sits 1.2-fold (0.09 log units) below what was measured; the range from low to high includes it.
By their numbers in this assay, from the lowest: compounds 2, 1 and 3 (each within the scatter of the next).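

In this assay the place opposite the ring nitrogen tolerates a complete exchange of group without a reading outside the scatter: a 1.6-fold higher number from compound 2 to compound 3 (0.20 log units; within the scatter), and a 1.2-fold higher number from compound 1 to compound 3 (0.08 log units; within the scatter). The earlier pair showed only that selenium and tellurium could be exchanged with the attached six-membered aromatic ring kept, whereas compound 3 has neither that ring nor either of those two atoms, and its 4-hydroxybut-1-yn-1-yl group brings a triple bond, a hydrogen-bond donor and a hydrogen-bond acceptor to the same place, so within these three compounds neither the ring nor the heavy atom is required for a reading of this size. No measured evidence is available to explain this result.

The compounds shown leave open whether any group at this place gives a step beyond the scatter, for instance an amine, a carboxylic acid or a longer chain ending in hydroxy. Going by these compounds, it also remains open what a change at the ethoxycarbonyl group would do, since all three compounds carry that group unchanged.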